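Amide aryl variation: step from compound 3 to compound 4

The source may report more compounds than this note shows. Statements on the series, on what has been measured and on what is new or still open speak of the compounds shown alone.

Measured compounds in an assay on isolated protein for inhibition of histone deacetylase 4 (Homo sapiens), with a stated time of 1 h; a lower number here means a stronger inhibitor, a higher number a weaker inhibitor:
- compound 1 `Cc1ccc(NC(=O)COc2ccc3cc(/C=C4/SC(=O)NC4=O)ccc3c2)cc1`: 1700 nM
- compound 2 `COc1cccc(NC(=O)COc2ccc3cc(/C=C4/SC(=O)NC4=O)ccc3c2)c1`: 1600 nM
- compound 3 `Cc1cc(Br)ccc1NC(=O)COc1ccc2cc(/C=C3/SC(=O)NC3=O)ccc2c1`: 550 nM

Compound 3 holds the lowest number of the three; its nearest neighbour is compound 2, and the steps of a 3.1-fold lower number from compound 1 to compound 3 (0.49 log units; beyond the scatter) and a 2.9-fold lower number from compound 2 to compound 3 (0.46 log units; beyond the scatter) both lie beyond the scatter, while a 1.1-fold lower number from compound 1 to compound 2 (0.03 log units; within the scatter) does not. Only the amide aryl group varies across the set.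

Compound 4 `O=C(COc1ccc2cc(/C=C3/SC(=O)NC3=O)ccc2c1)Nc1ccc(Cl)c(Cl)c1` differs from compound 3 only there: 3,4-dichlorophenyl in place of 4-bromo-2-methylphenyl on an amide-type nitrogen. Both groups carry ring halogen and neither carries a donor or acceptor. For the measured compounds named here, the two measured steps that bear on this change are those from compound 1 and compound 2 to compound 3, each modest and each moving to a halogen-bearing aryl; there is no measured step between two different halogenated aryls, so the size of the change from a bromo-methyl to a dichloro pattern is not anchored. The expectation for compound 4 in this assay is therefore a value near that of compound 3, a step of a 1.1-fold higher number from compound 3 to compound 4 (0.04 log units; within the scatter) that is not expected to exceed the scatter in either direction. The estimate for compound 4 is 600 nM, with a range from 250 nM to 1500 nM.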

Compound 4, half-maximal inhibitory concentration: 5500 nM
Compound 4: middle estimate off by 9.2-fold (0.96 log units), on the low side; measured number above the stated range.
By their numbers in this assay, from the lowest: compound 3; then compounds 2 and 1 (each within the scatter of the next); then compound 4.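

Ring halogen alone does not carry the lower number of compound 3 in this assay: the change to 3,4-dichlorophenyl gives a 10-fold higher number from compound 3 to compound 4 (1.00 log units; beyond the scatter), the largest step in the series so far. Compound 4 also ends above both aryl groups without halogen, with a 3.4-fold higher number from compound 2 to compound 4 (0.54 log units; beyond the scatter) and a 3.2-fold higher number from compound 1 to compound 4 (0.51 log units; beyond the scatter), so a halogen-bearing aryl here can lie on either side of those two compounds, and the whole substitution pattern matters rather than the presence of halogen. Nothing available accounts for the gap between the two halogenated aryls.

The compounds shown do not separate the contributions of the bromine and the methyl group in compound 3, nor those of the two chlorines in compound 4. From the compounds shown here alone, how an aminomethyl group or a carboxylic acid on this aryl ring would read in this assay also stays open.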